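The source may hold more compounds than are shown below. What is called first, only, known or untested is meant among the compounds shown, and "the series" means these compounds.

Measured so far:
Compound 1, `CCOC(=O)c1cnc(NC2CC2)n2nc(-c3ccco3)nc12`, gives 2260 nM in a functional assay on CHO cells for antagonist activity at adenosine receptor A2b (Homo sapiens); on this read-out lower numbers stand for stronger inhibition and higher numbers for weaker inhibition.
Compound 2, `CCOC(=O)c1cnc(N2CCCCC2)n2nc(-c3ccco3)nc12`, gives > 10000 nM in this assay; this figure is a limit of the assay, not a number.

On the numbers shown, compound 2 therefore stands at the weak end: the only step into it, an at least 4.4-fold higher number from compound 1 to compound 2 (0.64 log units; beyond the scatter), runs from cyclopropylamino to piperidin-1-yl and leaves compound 2 at the limit of > 10000 nM in this assay, at which 1 of the 2 values shown sits.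

The unmeasured compound 3, `CCOC(=O)c1cnc(N(C)C)n2nc(-c3ccco3)nc12`, differs from compound 2 by dimethylamino in place of piperidin-1-yl on an aromatic carbon. Within the data shown here, the one measured step that bears on this change is the same an at least 4.4-fold higher number from compound 1 to compound 2 (0.64 log units; beyond the scatter), which put the larger ring-containing group at the limit. Dimethylamino is smaller than piperidin-1-yl and, like it, carries no hydrogen-bond donor, so compound 3 is placed between the two measured compounds, without strong grounds for either end. Compound 3 is expected to give about 8000 nM in this assay, within 2500 nM to 30000 nM, which would mean an estimated at least 1.2-fold lower number from compound 2 to compound 3 (0.09 log units; that floor lies within the scatter), though a reading that again reaches only the limit would not be surprising.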

Compound 3, inhibition constant: > 10000 nM
Compound 3: a limit, no number; the forecaster's own chance of this, stated with the estimate: 40%; at least 1.2-fold (0.09 log units) between middle value and limit.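

Replacing cyclopropylamino with dimethylamino on the same aromatic carbon gives, in this assay, an at least 4.4-fold higher number from compound 1 to compound 3 (0.64 log units; beyond the scatter), so a second group, this one with no ring, also falls on the weak side of compound 1. Piperidin-1-yl and dimethylamino differ in heavy atoms and in the ring, yet each leaves its compound at a limit of the assay rather than at a number, so going from the larger to the smaller of these two groups brings back no measurable value. The step from compound 2 to compound 3 cannot be read, as both values are limits, and the three compounds now stand as one number and two limits: the limit of > 10000 nM in this assay, at which 2 of the 3 values shown sit.

As far as these compounds go, what stays open is which feature of cyclopropylamino goes with the measurable value in compound 1, the hydrogen on its nitrogen or its small carbon ring. From the compounds shown here alone, a methylamino or ethylamino group, or a plain amine, at this position would help to separate the two, and how far compound 2 and compound 3 lie past their limits also remains unknown.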